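Methyl for Chloro on the Fused Ring of Compound 1

The source may hold more compounds than are shown below. What is called first, only, known or untested is meant among the compounds shown, and "the series" means these compounds.

Three compounds sharing one core were measured in an assay on HL-60 cells for inhibition of glutathione S-transferase P (Homo sapiens), read by spectrophotometry, tested at 20 uM; on this read-out higher numbers stand for more inhibition at the one concentration tested (going by the name of the read-out) and lower numbers for less inhibition. Compound 1 `COc1ccc(/C=C2\CN(CC(=O)O)c3c(Cl)cccc3C2=O)c(OC)c1OC` gives 23.6%, the second highest of the three numbers. Compound 2 `Cc1ccc2c(c1)C(=O)/C(=C/c1ccc(Br)cc1)CN2CC(=O)O` gives 28.2%, and compound 3 `Cc1cc(C)cc(/C=C2\CN(CC(=O)O)c3c(C)cccc3C2=O)c1` gives 17.5%; both lie within the usual scatter of compound 1, so no order among the three can be claimed. The unmeasured compound 4 `COc1ccc(/C=C2\CN(CC(=O)O)c3c(C)cccc3C2=O)c(OC)c1OC` differs from compound 1 in one place: methyl in place of chloro on an aromatic carbon. Among the measured compounds shown here, no pair of measured compounds shows this exchange alone. Compound 3 also bears a methyl group and sits close to compound 1. The step is therefore expected to stay within the scatter, in no particular direction, as a number 1.6 percentage points lower from compound 1 to compound 4 (within the scatter). Compound 4 is estimated at 22%, within 10% to 34%.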

Compound 4, a percentage reported as inhibition, at one concentration (the size of the read-out at that concentration, not a potency): 1.57%
Estimate against measurement, compound 4: 20.4 percentage points above; the measured number lies below the stated range.
By their numbers in this assay, from the lowest: compound 4; then compounds 3, 1 and 2 (each within the scatter of the next, the first and the last beyond it).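

Among the compounds shown here, this position of the shared core is sensitive in this assay: methyl in place of chloro on this aromatic carbon gives a number 22 percentage points lower from compound 1 to compound 4 (beyond the scatter), the first step read between compounds that differ in one place. The exchange replaces one heavy atom with one heavy atom and leaves hydrogen-bond donors, acceptors and net charge unchanged, yet the number still moves. Nothing at hand bears on the reason for this step.

The compounds shown leave open how a fluoro group, an ethyl group or a nitrile on this carbon would read. They also leave open whether chloro is the better group here or methyl alone is the poor one.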